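Benzyl change on the bicyclic sulfonamide series: cytotoxicity outlook

The source may report more compounds than this note shows. Statements on the series, on what has been measured and on what is new or still open speak of the compounds shown alone.

Measured so far:
- compound 1, `CS(=O)(=O)Nc1ccc2c(c1)S(=O)(=O)N=C(C1=C(O)[C@H]3CCC[C@H]3N(Cc3ccc(F)c(F)c3)C1=O)N2`: > 1000 nM
- compound 2, `CS(=O)(=O)Nc1ccc2c(c1)S(=O)(=O)N=C(C1=C(O)C3CCCCC3N(C3CCCCC3)C1=O)N2`: > 33000 nM

In an ADME assay on Huh-7 cells (Homo sapiens) for cytotoxicity, with a stated time of 72 h (a higher number here means that more compound is tolerated, a lower number that less compound is tolerated), compound 1 gives only a limit, > 1000 nM, and no number. For compound 2 the value > 33000 nM is likewise a limit of this assay. So compound 1 stands at the limit of > 1000 nM in this assay, at which 1 of the 2 values shown sits, while the other value shown sits at the limit of > 33000 nM in this assay, at which 1 of the 2 values shown sits; no step between the two can be computed from this.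

Compound 3, `CS(=O)(=O)Nc1ccc2c(c1)S(=O)(=O)N=C(C1=C(O)[C@H]3CCC[C@H]3N(Cc3cccc(C(F)(F)F)c3)C1=O)N2`, has not yet been measured in this assay. It differs from compound 1 in one place: 3-(trifluoromethyl)phenyl in place of 3,4-difluorophenyl on a saturated chain carbon bound to an amide-type nitrogen in a ring. Cut one bond further out, the same difference reads 3,4-difluorobenzyl to 3-(trifluoromethyl)benzyl.

For the measured compounds named here, no measured step is available for this pair, and nothing among the measured compounds speaks for a change in this assay beyond the usual scatter. The expected step from compound 1 to compound 3 is therefore a step that the limit leaves unreadable from compound 1 to compound 3, that is none beyond the scatter. For compound 3 the estimate in this assay is 3000 nM, with a range from 700 nM to 30000 nM, most likely again reported as a limit.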

Compound 3, half-maximal cytotoxic concentration: > 33000 nM
Compound 3: no number, only a limit; the forecaster's own chance of this, stated with the estimate: 70%; at least 11-fold (1.04 log units) between middle value and limit.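

For the compounds shown here, compound 1 and compound 3 each give only a limit in this assay, and no step between them can be read. The compounds shown leave open whether 3-(trifluoromethyl)benzyl in place of 3,4-difluorobenzyl on the shared core shifts the half-maximal cytotoxic concentration at all and, if it does, in which direction and how far.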